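A few compounds are considered here, and "the series" means these few. Any claim that something is new, unique, unknown or untested is made for them only; others in the source may bear on it.

Three compounds that share one core were tested in a functional assay on HeLa cells (Homo sapiens) for cytotoxicity, read by MTT assay, with a stated time of 2 days, tested at 1 uM; on this read-out higher numbers stand for a weaker effect at the one concentration tested and lower numbers for a stronger effect. Compound 1 `CC(=O)c1cc(-c2ccc(F)cc2)cc2cc(-c3ccc(F)cc3)[nH]c12` gives 71.6%. Compound 2 `COc1ccc(-c2cc(C(C)=O)c3[nH]c(-c4ccc(F)cc4)cc3c2)cc1` carries methoxy in place of fluoro on an aromatic carbon, and in this assay compound 2 gives 56.1%, a step of a number 15.5 percentage points lower from compound 1 to compound 2 (beyond the scatter). Compound 3 `CC(=O)c1cc(/C=C/c2ccc(F)cc2)cc2cc(-c3ccc(F)cc3)[nH]c12` has a different core: the two cores differ by 2-(4-fluorophenyl)ethenyl in place of 4-fluorophenyl on an aromatic carbon, and in this assay compound 3 gives 53.7%. Compound 4 `COc1ccc(-c2cc3cc(/C=C/c4ccc(F)cc4)cc(C(C)=O)c3[nH]2)cc1` has not yet been measured. It carries methoxy in place of fluoro on an aromatic carbon on the core of compound 3, the same change already seen once, at the same place. The step to compound 4 is expected to be a number 12.7 percentage points lower from compound 3 to compound 4 (beyond the scatter), resting on the earlier step of a number 15.5 percentage points lower from compound 1 to compound 2 (beyond the scatter), though a single example is a thin basis. Compound 4 is therefore estimated at 41%, between 27% and 57%.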

Compound 4, a percentage reported as activity, at one concentration (the size of the read-out at that concentration, not a potency): 67.1%
Compound 4: middle estimate off by 26.1 percentage points, on the low side; measured number above the stated range.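

On the core of compound 3, methoxy in place of fluoro gives a number 13.4 percentage points higher from compound 3 to compound 4 (beyond the scatter) in this assay, which here means a weaker effect, whereas on the core of compound 1 the same change gave a stronger one. The two steps point in opposite directions: the same change on two cores in this assay, a number 15.5 percentage points lower (beyond the scatter) from compound 1 to compound 2 and a number 13.4 percentage points higher (beyond the scatter) from compound 3 to compound 4, 28.9 percentage points apart, beyond the scatter of two such steps. Within the data shown here, this shows that the step seen on one core did not carry over to the other, but with only one pair on each core it does not show why, or what this change would do on a further core.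

The compounds shown leave open whether another group at the same place, such as an amine or a carboxylic acid, would also behave differently on the two cores.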